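Triazine piperazines on breast cancer cells: a chlorine-to-methoxy swap

The source may hold more compounds than are shown below. What is called first, only, known or untested is meant among the compounds shown, and "the series" means these compounds.

Measured compounds:
compound 1, `COc1ccc(-c2nnc(N3CCN(C(=O)CN4CCN(c5ccccc5Cl)CC4)CC3)nc2-c2ccc(OC)cc2)cc1`, > 814000 nM
compound 2, `COc1ccc(-c2nnc(N3CCN(C(=O)CN4CCN(c5cccc(OC)c5)CC4)CC3)nc2-c2ccc(OC)cc2)cc1`, > 821000 nM
compound 3, `O=C(CN1CCN(c2ccccc2Cl)CC1)N1CCN(c2nnc(-c3ccc(Cl)cc3)c(-c3ccc(Cl)cc3)n2)CC1`, 396000 nM

Of the compounds shown here, three have been tested in a functional assay on MCF7 cells (Homo sapiens) for cytotoxicity, read by MTT assay, with a stated time of 24 h; a lower number here means a stronger inhibitor, a higher number a weaker inhibitor. Compound 1, `COc1ccc(-c2nnc(N3CCN(C(=O)CN4CCN(c5ccccc5Cl)CC4)CC3)nc2-c2ccc(OC)cc2)cc1`, reaches only a limit of that assay, > 814000 nM. Compound 2, `COc1ccc(-c2nnc(N3CCN(C(=O)CN4CCN(c5cccc(OC)c5)CC4)CC3)nc2-c2ccc(OC)cc2)cc1`, likewise gives only a limit, > 821000 nM. Among the measured compounds shown here, compound 3, `O=C(CN1CCN(c2ccccc2Cl)CC1)N1CCN(c2nnc(-c3ccc(Cl)cc3)c(-c3ccc(Cl)cc3)n2)CC1`, is the one compound with a number in this assay, 396000 nM.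

Compound 2 differs from compound 1 in one place, (3-methoxyphenyl in place of 2-chlorophenyl on an amine nitrogen in a ring). The step in this assay, a step that the two limits leave unreadable from compound 1 to compound 2, cannot be sized, since the result of compound 1 is a limit, (the limit of > 814000 nM in this assay, at which 1 of the 3 values shown sits). The result of compound 2 is also a limit, (the limit of > 821000 nM in this assay, at which 1 of the 3 values shown sits). Compound 3 has a different core from compound 1; the difference between the two cores is not broken down here.

Compound 4, `COc1cccc(N2CCN(CC(=O)N3CCN(c4nnc(-c5ccc(Cl)cc5)c(-c5ccc(Cl)cc5)n4)CC3)CC2)c1`, has not yet been measured in this assay. It stands to compound 3 as compound 2 stands to compound 1, with the same change, (3-methoxyphenyl in place of 2-chlorophenyl on an amine nitrogen in a ring), at the same place. For the measured compounds named here, as the only earlier instance of this change left no readable step, the expectation for compound 4 leans on compound 3 alone, whose value is 396000 nM. The step is estimated at a 1.3-fold higher number from compound 3 to compound 4 (0.10 log units; within the scatter), close to no change. Compound 4 is therefore expected to give about 500000 nM in this assay, within roughly 200000 nM to 1200000 nM.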

Compound 4, half-maximal inhibitory concentration: 149000 nM
Compound 4: the middle estimate sits 3.4-fold (0.53 log units) above what was measured, outside the stated range (below it).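

In this assay, putting 3-methoxyphenyl in place of 2-chlorophenyl on the core of compound 3 gives a 2.7-fold lower number from compound 3 to compound 4 (0.42 log units; beyond the scatter), a modest step that lies beyond the usual scatter. The same change on the core of compound 1 cannot be sized, and compound 1 stands only at a limit of the assay: the limit of > 814000 nM in this assay, at which 1 of the 4 values shown sits. Compound 2 also stands only at a limit of the assay, so the change has a readable size on one core alone, and nothing shows whether that step carries over to the other core or fails to: the limit of > 821000 nM in this assay, at which 1 of the 4 values shown sits.

Two things change at once in this swap, the chlorine giving way to a methoxy group and the substituent taking a different place on the phenyl ring, and the compounds shown do not separate them. Going by these compounds, it remains open how a plain phenyl group, or a hydroxyl or an amine in place of the methoxy group, would read in this assay on either core, and whether a group of this kind could bring the core of compound 1 to a readable number.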